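A few compounds are considered here, and "the series" means these few. Any claim that something is new, unique, unknown or untested is made for them only; others in the source may bear on it.

Measured compounds and their half-maximal cytotoxic concentrations:

compound 1 `CC(=O)OCCc1c(-c2ccccc2Cl)c2cc(Cl)ccc2[nH]c1=O`: 27000 nM
compound 2 `CCCC(=O)OCCc1c(-c2ccccc2Cl)c2cc(Cl)ccc2[nH]c1=O`: 52000 nM
compound 3 `O=C(O)CCCC(=O)OCCc1c(-c2ccccc2Cl)c2cc(Cl)ccc2[nH]c1=O`: 110000 nM

In an ADME assay on HepG2 2.2.15 cells (Homo sapiens) for cytotoxicity (a lower number here means that less compound is tolerated, a higher number that more compound is tolerated), compound 1 gives the lowest of the three numbers. Compound 2 lies nearest to it, the step being a 1.9-fold higher number from compound 1 to compound 2 (0.28 log units; within the scatter), and compound 3 lies furthest, with a 4.1-fold higher number from compound 1 to compound 3 (0.61 log units; beyond the scatter). Between the two larger esters the step is a 2.1-fold higher number from compound 2 to compound 3 (0.33 log units; beyond the scatter).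

Compound 4 `O=C(OCCc1c(-c2ccccc2Cl)c2cc(Cl)ccc2[nH]c1=O)C1CCCC1` differs from compound 1 in one place: cyclopentyl in place of methyl on a carbonyl carbon. Of the measured steps, the one that bears most on this change is the enlargement of the group on the carbonyl carbon without any new donor or acceptor, which gave a 1.9-fold higher number from compound 1 to compound 2 (0.28 log units; within the scatter). The steps to compound 3 each bring in a carboxy group that compound 4 does not carry, so they bear less on it. The expected step in this assay is therefore small and upward, possibly none beyond the scatter: a 1.5-fold higher number from compound 1 to compound 4 (0.17 log units; within the scatter). Compound 4 is estimated to give 40000 nM, with a range of 20000 nM to 90000 nM.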

Compound 4, half-maximal cytotoxic concentration: 46000 nM
Compound 4: middle estimate off by 1.2-fold (0.06 log units), on the low side; measured number inside the range.
By their numbers in this assay, from the lowest: compounds 1, 4 and 2 (each within the scatter of the next); then compound 3.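

In this assay, a ring on the carbonyl carbon reads no differently from an open chain in these compounds: cyclopentyl in place of methyl gives a 1.7-fold higher number from compound 1 to compound 4 (0.23 log units; within the scatter) and cyclopentyl in place of propyl gives a 1.1-fold lower number from compound 2 to compound 4 (0.05 log units; within the scatter) as the step from the propyl ester. The change from 3-carboxypropyl to cyclopentyl, by contrast, gives a 2.4-fold lower number from compound 3 to compound 4 (0.38 log units; beyond the scatter) and so stands beyond the scatter, which sets compound 3 apart from compound 4 as it does from compound 1. Nothing shown gives a reason for these numbers.

As far as these compounds go, whether an amine at the end of the chain on this carbonyl carbon would shift the number as the carboxy group does remains open. So does whether a phenyl ring there would behave like cyclopentyl, and whether a longer chain ending in a carboxylic acid would follow compound 3.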